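The compounds below may be only part of what the source reports. "The series", "measured", "known", "first", "only" and "open" are said of these compounds alone.

Compound 1 `CS(=O)(=O)Nc1ccc2c(c1)S(=O)(=O)N=C(C1=C(O)C3CCCC3N(CCC3CC3)C1=O)N2`: 0.417 h
Compound 2 `CS(=O)(=O)Nc1ccc2c(c1)S(=O)(=O)N=C(C1=C(O)[C@H]3CCC[C@H]3N(Cc3ccc(F)c(F)c3)C1=O)N2`: > 1 h
Compound 3 `CS(=O)(=O)Nc1ccc2c(c1)S(=O)(=O)N=C(C1=C(O)[C@H]3CCC[C@H]3N(Cc3ccc(C(F)(F)F)cc3)C1=O)N2`: > 1 h

Among the measured compounds shown here, in an in vitro ADME assay on microsomes from liver (Homo sapiens) for metabolic stability (on this read-out lower numbers stand for a shorter-lived compound and higher numbers for a longer-lived compound), compound 1 gives 0.417 h and is the only compound of the three with an actual number. For compound 2 the result is a limit of the assay, > 1 h, not a number. For compound 3 the result is likewise a limit of the assay, > 1 h. For the measured compounds named here, the one measured step between neighbours, a step that the two limits leave unreadable from compound 2 to compound 3, therefore cannot be read in size, since both of its ends are limits.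

The step to compound 4 `CS(=O)(=O)Nc1ccc2c(c1)S(=O)(=O)N=C(C1=C(O)C3CCCC3N(Cc3ccccc3)C1=O)N2` is phenyl in place of cyclopropylmethyl on a saturated chain carbon bound to an amide-type nitrogen in a ring. Both compounds that carry an aromatic group on that chain carbon reach the limit, as summarised by the limit of > 1 h in this assay, at which 2 of the 3 values shown sit, while compound 1, with cyclopropylmethyl there, gives a number well short of it. Going by the values given here, no measured step maps exactly onto this change, so the expectation rests on that contrast alone: a longer half-life, plausibly reaching the limit itself.

Compound 4 is estimated to give 1 h, with a likely range from 0.5 h to 2 h. The step this estimate means is a 2.4-fold higher number from compound 1 to compound 4 (0.38 log units; beyond the scatter), expected to run towards longer survival and to exceed the usual scatter.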

Compound 4, half-life: 0.833 h
Estimate against measurement, compound 4: 1.2-fold (0.08 log units) above; the measured number falls inside the stated range.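

In this assay putting phenyl in place of cyclopropylmethyl on a saturated chain carbon bound to an amide-type nitrogen in a ring gives a 2.0-fold higher number from compound 1 to compound 4 (0.30 log units; within the scatter) and so, taken alone, does not separate the two compounds. Until now, the contrast at this position rested on compounds that sit at a limit and hold no number, whereas compound 4 is the only compound shown with an aromatic ring there that returns an actual number. The other two compounds with an aromatic ring there remain limits, and they also differ from compound 4 in their ring substituents and their drawn stereochemistry, so no size can be read against them: the limit of > 1 h in this assay, at which 2 of the 4 values shown sit.

From the compounds shown here alone, it remains open whether a different group on that chain carbon, such as a pyridine ring or a longer chain ending in an amine, would move the half-life of compound 1 beyond the scatter. Also open, going by these compounds, are how far compound 2 and compound 3 lie past their limit and whether a single fluorine on the phenyl of compound 4, with nothing else changed, would shift the read-out.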